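Fluorine on the Carbamate Chain: an Efficacy Estimate

The compounds below may be only part of what the source reports. "The series", "measured", "known", "first", "only" and "open" are said of these compounds alone.

Of the compounds shown here, two from this series have been measured in a functional assay on CHO-K1 cells with Glucose-dependent insulinotropic receptor (Homo sapiens) as the target, read by a luciferase reporter, with a stated time of 5 h; on this read-out lower numbers stand for smaller maximal responses and higher numbers for larger maximal responses. Compound 1 `CC(C)OC(=O)N1CCC(Oc2ncnc3c2CCN3c2ccc(S(C)(=O)=O)cc2F)CC1` carries an isopropyl group on the oxygen next to the carbonyl of its carbamate, and in this assay compound 1 gives 91%. Compound 2 `CCCOC(=O)N1CCC(Oc2ncnc3c2CCN3c2ccc(S(C)(=O)=O)cc2F)CC1` has a propyl group in that place, and in this assay compound 2 gives 111%. Within the data shown here, the only step available, a number 20 percentage points higher from compound 1 to compound 2 (beyond the scatter), shows that lengthening the chain lifted the maximal response beyond the usual scatter, and compound 2 therefore stands highest of the two numbers, with compound 1 as its only neighbour.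

Compound 3 `CS(=O)(=O)c1ccc(N2CCc3c(OC4CCN(C(=O)OCCF)CC4)ncnc32)c(F)c1` differs from compound 2 by fluoro in place of methyl on a saturated chain carbon, two bonds along the chain from an oxygen next to a carbonyl group. Among the measured compounds shown here, no measured step replaces a methyl with a fluoro, so the one step known gives only indirect guidance: it shows that the end of this chain can shift the read-out by a modest amount. Compound 3 is therefore expected to stay close to compound 2, with an estimated change of a number 11 percentage points lower from compound 2 to compound 3 (beyond the scatter). The estimate for compound 3 is 100%, within a range from 80% to 120%.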

Compound 3, largest response reached (reported as percent of maximum), in percent of the reference or control that the assay uses: 86%
For compound 3 the middle estimate is 14 percentage points above the measured one, within the range that was stated.
By their numbers in this assay, from the lowest: compounds 3 and 1 (each within the scatter of the next); then compound 2.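

In this assay the exact atom at the end of the chain turns out to matter: putting fluoro in place of methyl on a saturated chain carbon, two bonds along the chain from an oxygen next to a carbonyl group, gives a number 25 percentage points lower from compound 2 to compound 3 (beyond the scatter) and so removes the gain that the propyl compound had shown. An unbranched chain is therefore not enough on its own to keep the higher response, and the step for 2-fluoroethyl in place of isopropyl reads a number 5 percentage points lower from compound 1 to compound 3 (within the scatter), which leaves these two compounds indistinguishable on this read-out. No available evidence explains why this one replacement lowers the maximal response.

Going by these compounds, it remains open whether the drop is specific to fluoro or would also appear with other groups at this place, such as a hydroxyl, a methoxy or a nitrile. The compounds shown also leave open how a longer chain such as butyl would behave on the same carbamate oxygen.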